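This account rests on a few compounds, and the source may have more. Where it says the series, first, only, none or still open, it means among the compounds named here.

Of the compounds shown here, three from this series have been measured in a functional assay on HeLa cells (Homo sapiens) for cytotoxicity, read by WST assay, with a stated time of 48 h; on this read-out lower numbers stand for stronger inhibition and higher numbers for weaker inhibition. Compound 1 `O[C@@H](c1ccccc1)[C@H]1CO[C@H](c2ccccc2)[C@@H](C/C=C/c2ccccc2)C1` gives 6060 nM in this assay, compound 2 `COc1cccc(/C=C/C[C@H]2C[C@@H]([C@@H](O)c3ccccc3)CO[C@@H]2c2ccccc2)c1` gives 10900 nM, and compound 3 `COc1ccc(/C=C/C[C@H]2C[C@@H]([C@@H](O)c3ccc(OC)c(OC)c3)CO[C@@H]2c2ccc(OC)c(OC)c2)cc1OC` gives 23800 nM, the highest of the three numbers. The change from compound 2 to compound 1 is hydrogen in place of methoxy on an aromatic carbon; it made a 1.8-fold lower number from compound 2 to compound 1 (0.25 log units; within the scatter). How the core of compound 3 differs from that of compound 2 is not broken down here. Compound 4 `COc1cccc([C@H]2OC[C@H]([C@@H](O)c3ccc(OC)c(OC)c3)C[C@@H]2C/C=C/c2ccc(OC)c(OC)c2)c1` has not yet been measured; it relates to compound 3 through (hydrogen in place of methoxy on an aromatic carbon). Within the data shown here, this is the same kind of change as the one between compound 2 and compound 1, but not the same: the earlier one sat meta to a large group, whereas this one sits ortho to a methoxy group and para to a large group. Resting on the measured step, which read a 1.8-fold lower number from compound 2 to compound 1 (0.25 log units; within the scatter), compound 4 is expected to show a step of about a 1.6-fold lower number from compound 3 to compound 4 (0.20 log units; within the scatter). The estimate for compound 4 in this assay is 15000 nM, expected to fall between 6000 nM and 40000 nM.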

Compound 4, half-maximal inhibitory concentration: 21800 nM
The estimate for compound 4 lay 1.5-fold (0.16 log units) below the measured number; low and high end bracket the measured number.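

In this assay, hydrogen in place of methoxy, here 3,4-dimethoxyphenyl to 3-methoxyphenyl, reads a 1.1-fold lower number from compound 3 to compound 4 (0.04 log units; within the scatter), and set beside the earlier case, the two cores agree: the same change on two cores in this assay, a 1.8-fold lower number (0.25 log units; within the scatter) from compound 2 to compound 1 and a 1.1-fold lower number (0.04 log units; within the scatter) from compound 3 to compound 4, 1.6-fold (0.22 log units) apart, within the scatter of two such steps

In these two pairs, then, the change carries from one core to the other, and on neither core does its step stand out from the scatter. This does not show that the change is without effect elsewhere in the series, since it rests on two pairs only, and the place of the change on the ring is not the same in both.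

The compounds shown leave open whether a group other than methoxy at these places, such as a hydroxyl, a fluorine atom or an amine, would give a step beyond the scatter. They also leave open which of the methoxy groups on compound 3 account for its higher number relative to compound 1, as those two compounds differ in more than one place.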